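From compound 3 to compound 4: expected step

The source may hold more compounds than are shown below. What is called first, only, known or untested is meant among the compounds shown, and "the series" means these compounds.

In a functional assay on SNB-75 cells (Homo sapiens) for inhibition, read by sulforhodamine B assay, with a stated time of 48 h (on this read-out higher numbers stand for weaker inhibition of growth and lower numbers for stronger inhibition of growth), compound 3 (`COc1cc(-c2nn(-c3cccc(NC(=O)Nc4cccc(C(F)(F)F)c4)c3)cc2-c2ccncc2)ccc1Cl`) gives 4500 nM and compound 2 (`COc1cc(-c2nn(-c3cccc(NC(=O)Nc4ccc(Cl)c(Cl)c4)c3)cc2-c2ccncc2)ccc1Cl`) gives 5170 nM, the two being level within the scatter. Compound 1 (`O=C(Nc1cccc(-n2cc(-c3ccncc3)c(-c3ccc(Cl)c(O)c3)n2)c1)Nc1cccc(C(F)(F)F)c1`) gives only a limit, > 32500 nM.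

Compound 4 (`COc1cc(-c2nn(-c3cccc(NC(=O)c4ccccc4)c3)cc2-c2ccncc2)ccc1Cl`) carries phenyl in place of (3-(trifluoromethyl)phenyl)amino on a carbonyl carbon.

Among the measured compounds shown here, two measured steps bear on this change, both only in part. Exchanging the aromatic group on the amide-type nitrogen gave a 1.1-fold lower number from compound 2 to compound 3 (0.06 log units; within the scatter), so that exchange alone offers no ground for expecting a large shift. Methyl in place of hydrogen on an oxygen on an aromatic ring gave an at least 7.2-fold lower number from compound 1 to compound 3 (0.85 log units; beyond the scatter), which lies beyond the scatter. That methyl remains in compound 4, so this step does not transfer. For the measured compounds named here, no measured step covers loss of the amino nitrogen.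

A modest move towards a higher number, meaning weaker inhibition of growth, is therefore expected in this assay. The estimated step is a 1.6-fold higher number from compound 3 to compound 4 (0.19 log units; within the scatter). For compound 4 the estimate is 7000 nM, with an expected range of 3000 nM to 25000 nM.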

Compound 4, concentration for total growth inhibition: > 100000 nM
Compound 4: a limit, no number; the forecaster's own chance of this, stated with the estimate: 25%; at least 14-fold (1.15 log units) between middle value and limit.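

In this assay, phenyl in place of (3-(trifluoromethyl)phenyl)amino on a carbonyl carbon gives an at least 22-fold higher number from compound 3 to compound 4 (1.34 log units; beyond the scatter), and phenyl in place of (3,4-dichlorophenyl)amino gives an at least 19-fold higher number from compound 2 to compound 4 (1.28 log units; beyond the scatter). Exchanging the aromatic group while keeping the amino nitrogen had given only a 1.1-fold lower number from compound 2 to compound 3 (0.06 log units; within the scatter), so this position responds far more to the full replacement than to that exchange. Compound 4 reads only as a limit of the assay, so the full size of the step stays unknown: the limit of > 100000 nM in this assay, at which 1 of the 4 values shown sits.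

The change removes the amino nitrogen, with its hydrogen-bond donor, and the ring substituents together, and the compounds shown do not separate these two losses. Plain phenylamino on the carbonyl carbon, or 3-(trifluoromethyl)benzyl, would be needed to tell them apart.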